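Aspartate Diester Variant of an Indolyl Maleimide Series

The source may hold more compounds than are shown below. What is called first, only, known or untested is meant among the compounds shown, and "the series" means these compounds.

Measured compounds:
compound 1 `COC(=O)[C@H](NC(=O)Cn1cc(C2=C(c3c[nH]c4ccccc34)C(=O)N(C)C2=O)c2ccccc21)[C@@H](C)O` gives 21400 nM in a functional assay on A2780 cells (Homo sapiens) for cytotoxicity, read by MTT assay, with a stated time of 24 h; a higher number here means a weaker inhibitor, a lower number a stronger inhibitor
compound 2 `COC(=O)CCNC(=O)Cn1cc(C2=C(c3c[nH]c4ccccc34)C(=O)N(C)C2=O)c2ccccc21` gives 44500 nM in this assay

Going by the values given here, compound 2 stands at the highest of the two numbers so far; its nearest neighbour is compound 1, and the step of a 2.1-fold higher number from compound 1 to compound 2 (0.32 log units; beyond the scatter) separates them. Compound 3 `COC(=O)C[C@@H](NC(=O)Cn1cc(C2=C(c3c[nH]c4ccccc34)C(=O)N(C)C2=O)c2ccccc21)C(=O)OC` has not yet been measured in this assay. It differs from compound 2 by methoxycarbonyl in place of hydrogen on a saturated chain carbon bound to an amide-type nitrogen and a saturated chain carbon. Among the compounds with values here, the only step that bears on this change is a 2.1-fold higher number from compound 1 to compound 2 (0.32 log units; beyond the scatter), which shows that removing a branched substituent from the carbon bound to the amide-type nitrogen gave a modest weakening. Restoring a branch at that carbon, here a methoxycarbonyl, is therefore expected to move compound 3 back toward the level of compound 1, by a modest amount if at all. Compound 3 is estimated at 28000 nM in this assay, a step of a 1.6-fold lower number from compound 2 to compound 3 (0.20 log units; within the scatter), with a range from 12000 nM to 65000 nM.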

Compound 3, half-maximal inhibitory concentration: 15400 nM
For compound 3 the middle estimate is 1.8-fold (0.26 log units) above the measured one; measured number inside the range.
By their numbers in this assay, from the lowest: compounds 3 and 1 (each within the scatter of the next); then compound 2.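

In this assay, methoxycarbonyl in place of hydrogen on the saturated chain carbon bound to an amide-type nitrogen and a saturated chain carbon gives a 2.9-fold lower number from compound 2 to compound 3 (0.46 log units; beyond the scatter), so a second kind of branch at this carbon also goes with a lower number than the unbranched chain of compound 2. Exchanging 1-hydroxyethyl for (methoxycarbonyl)methyl gives a 1.4-fold lower number from compound 1 to compound 3 (0.14 log units; within the scatter), which leaves the two branched compounds unordered and shows that the lower number does not depend on the hydroxyl of compound 1. Nothing available accounts for either step.

As far as these compounds go, whether a carboxylic acid in place of the methyl esters would keep this level remains open. So does the effect of an amine or a longer chain on this carbon.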